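The source may hold more compounds than are shown below. What is called first, only, known or untested is meant among the compounds shown, and "the series" means these compounds.

Compound 1 `O=C1c2ccccc2N(COCc2ccccc2)S(=O)(=O)N1COCc1ccccc1`: 27700 nM
Compound 2 `O=S1(=O)N=C(OCc2ccccc2)c2ccccc2N1Cc1ccc(Cl)c(Cl)c1`: 30500 nM
Compound 3 `O=C(OCOCN1c2ccccc2C(=O)N(Cc2ccccc2)S1(=O)=O)c1ccccc1`: 100000 nM

In a functional assay on CCRF-CEM cells (Homo sapiens) for inhibition (a higher number here means that more compound is tolerated, a lower number that less compound is tolerated), compound 1 gives the lowest of the three numbers. Compound 2 sits close to it, within the usual scatter, so the two cannot be told apart. Compound 3 gives a clearly higher number, beyond the scatter, so more of compound 3 is tolerated than of compound 1.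

Compound 4 `O=C1c2ccccc2N(Cc2ccccc2)S(=O)(=O)N1COCc1ccccc1` has not yet been tested. It differs from compound 1 by one change: phenyl in place of benzyloxy on a saturated chain carbon bound to a sulfonamide nitrogen in a ring. Going by the values given here, no measured pair shows this exact change, so the step from compound 1 to compound 4 is expected to be small, without a firm direction, and likely no larger than the scatter: a 1.1-fold higher number from compound 1 to compound 4 (0.03 log units; within the scatter). Compound 4 is estimated to give 30000 nM in this assay, with a range from 10000 nM to 100000 nM.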

Compound 4, half-maximal cytotoxic concentration: 100000 nM
Compound 4: middle estimate off by 3.3-fold (0.52 log units), on the low side, within the range that was stated.
By their numbers in this assay, from the lowest: compounds 1 and 2 (each within the scatter of the next); then compounds 3 and 4 (each within the scatter of the next).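

In this assay the swap of benzyloxy for phenyl on this chain carbon, which turns (benzyloxy)methyl into benzyl, gives a 3.6-fold higher number from compound 1 to compound 4 (0.56 log units; beyond the scatter) and so means that more compound is tolerated. Going by these compounds alone, this shows that the group on the carbon bound to the sulfonamide nitrogen can shift the number beyond the scatter, which no earlier pair could show. Nothing available explains this difference. Still open, on these data alone, is how an amine, a carboxylic acid or a longer chain at this place would read.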